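The compounds below may be only part of what the source reports. "The series", "measured", "known", "first", "only" and "open" are said of these compounds alone.

In an ADME assay on Raji cells (Homo sapiens) for cytotoxicity, read by luminescence, with a stated time of 72 h (on this read-out lower numbers stand for an effect already at smaller amounts and higher numbers for an effect only at larger amounts of compound), compound 1 (`CCOC(=O)c1c(-c2cccc(-c3ccccc3)c2)[nH]c2cc(OC)ccc2c1=O`) gives > 21500 nM as a limit and not a number. Compound 2 (`CCOC(=O)c1c(-c2cccc(OC(F)(F)F)c2)[nH]c2cc(OC)ccc2c1=O`) gives > 21500 nM in this assay and this too is only a limit, so its place in the series has no number attached.

Compound 3 (`CCOC(=O)c1c(-c2cccc(OC(F)(F)F)c2)[nH]c2cc(C(F)(F)F)ccc2c1=O`) follows from compound 2 through a single change, trifluoromethyl in place of methoxy on an aromatic carbon and the rest of the structure stays as it is.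

Going by the values given here, the one measured step is a step that the two limits leave unreadable from compound 1 to compound 2 and it concerns a different place in the structure, with no size to carry over. Among the compounds with values here, no measured step covers the exchange of methoxy for trifluoromethyl.

No shift beyond the scatter is therefore expected in this assay because the limit of > 21500 nM in this assay, at which 2 of the 2 values shown sit, is the only footing available. The expected step is a number no higher from compound 2 to compound 3 (the limit leaves the size open) and a direction cannot be assigned to it. For compound 3 the estimate is 21500 nM with an expected range from 10000 nM to 40000 nM and a report as a limit once more is the likeliest outcome.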

Compound 3, half-maximal effective concentration: > 21500 nM
Compound 3 gave a limit, no number; the forecaster's own chance of this, stated with the estimate: 85%; the middle value lies on the limit itself.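

In this assay compound 3 gives > 21500 nM, a limit and not a number. No step can be read from compound 2 to compound 3. The compounds shown leave open what number any of them would reach in this assay, and whether trifluoromethyl in place of methoxy shifts it at all, with a single limit shared: the limit of > 21500 nM in this assay, at which 3 of the 3 values shown sit.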